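Methyl on sulfur in place of propylcarbonyl

The source may hold more compounds than are shown below. What is called first, only, known or untested is meant among the compounds shown, and "the series" means these compounds.

In a functional assay on A549 cells (Homo sapiens) for inhibition, read by MTT assay, with a stated time of 96 h (on this read-out higher numbers stand for weaker inhibition of growth and lower numbers for stronger inhibition of growth), compound 1 (`O=C(OCc1ccccc1)SCCCCCCNC(=O)c1cc(-c2ccncc2)n[nH]1`) gives 13400 nM and compound 2 (`CCCC(=O)SCCCCCCNC(=O)c1cc(-c2ccncc2)n[nH]1`) gives 15100 nM while compound 3 (`CCCCCCCC/C=C\CCCCCCCC(=O)SCCCCCCNC(=O)c1cc(-c2ccncc2)n[nH]1`) gives 33300 nM as a clearly higher number than compound 2. Compound 2 therefore sits within the scatter of compound 1, with compound 3 beyond the scatter from it.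

Compound 4 (`CSCCCCCCNC(=O)c1cc(-c2ccncc2)n[nH]1`) is still unmeasured. Its difference from compound 2 is methyl in place of propylcarbonyl on a sulfur.

Going by the values given here, the only measured step bearing directly on this is a 1.1-fold higher number from compound 1 to compound 2 (0.05 log units; within the scatter) (propyl in place of benzyloxy on a carbonyl carbon). Among the compounds with values here, that step retains the carbonyl, which compound 4 lacks, so no measured step covers this change. Compound 3 at 33300 nM shows only that the number can rise among these compounds, so a step toward a higher number is expected, with low confidence.

The expected step is a 2.3-fold higher number from compound 2 to compound 4 (0.37 log units; beyond the scatter) (an estimate). For compound 4 the estimated value is 35000 nM (expected range 14000 nM to 90000 nM).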

Compound 4, concentration for 50% growth inhibition: > 50000 nM
Compound 4 gave a limit, no number; the forecaster's own chance of this, stated with the estimate: 25%; middle value at least 1.4-fold (0.15 log units) away from the limit.
By their numbers in this assay, from the lowest: compounds 1 and 2 (each within the scatter of the next); then compound 3. At a limit, above all of these: compound 4.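

In this assay, compound 4 stands at a limit and gives no number: the limit of > 50000 nM in this assay, at which 1 of the 4 values shown sits. At this sulfur, exchanging the group on the carbonyl left the number within the scatter, as in a 1.1-fold higher number from compound 1 to compound 2 (0.05 log units; within the scatter), whereas replacing the whole group with methyl gives an at least 3.3-fold higher number from compound 2 to compound 4 (0.51 log units; beyond the scatter) and, from the benzyloxycarbonyl compound, an at least 3.7-fold higher number from compound 1 to compound 4 (0.57 log units; beyond the scatter). Among the compounds shown, only compound 4 lacks a carbonyl on the sulfur and only compound 4 stands at the limit, so these steps are bounded on one side only.

As far as these compounds go, whether the loss of the carbonyl or the shortening of the group carries the step remains open. A free thiol, or a longer alkyl chain on the sulfur with no carbonyl, would separate the two readings.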